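The compounds below may be only part of what the source reports. "The series", "measured", "known", "first", "only" and "open" are said of these compounds alone.

Measured compounds:
compound 1, `Cc1cc(NCc2ccccn2)n2ncc(-c3ccc(F)cc3)c2n1`, < 5000 nM
compound 2, `Cc1cc(NCc2cnccn2)n2nc(C)c(-c3ccccc3)c2n1`, 7100 nM

Of the compounds shown here, two have been measured in a physicochemical assay for solubility, read by HPLC, using the shake flask method, measured as kinetic solubility, with a stated time of 2 h, at pH 7.4; a higher number here means a more soluble compound, a lower number a less soluble compound. Compound 2 gives 7100 nM in this assay, and this is the only actual number among the two results shown. Compound 1 is reported only as a limit of this assay, < 5000 nM, so no number is known for it; this is the limit of < 5000 nM in this assay, at which 1 of the 2 values shown sits. Among the compounds with values here, with a single number and a single limit, no step between two measured compounds can be stated, and nothing can be said about how the two compounds compare beyond what the limit and the number themselves show.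

The unmeasured compound 3, `Cc1cc(NCc2cccs2)n2nc(C)c(-c3ccccc3)c2n1`, differs from compound 2 in one place: thiophen-2-yl in place of pyrazin-2-yl on a saturated chain carbon bound to a nitrogen on an aromatic ring. Within the data shown here, since no measured step covers a change of this kind, the size of the step in this assay is uncertain. A modest downward step is expected, a 2.0-fold lower number from compound 2 to compound 3 (0.31 log units; beyond the scatter), though it could also fall within the scatter. Compound 3 is therefore estimated at 3500 nM, with a likely range from 900 nM to 12000 nM.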

Compound 3, solubility: < 5000 nM
Compound 3 ended at the assay's limit; the forecaster's own chance of this, stated with the estimate: 45%; the middle value does not contradict the limit.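

In this assay, the place on a saturated chain carbon bound to a nitrogen on an aromatic ring now has its first step that can be read, at least in part: putting thiophen-2-yl in place of pyrazin-2-yl gives an at least 1.4-fold lower number from compound 2 to compound 3 (0.15 log units; that floor lies within the scatter). From the compounds shown here alone, compound 3 is reported as < 5000 nM, which is a limit and not a number, so the step printed here is only a floor on the change, and the true size of the change stays unknown. The step can be read no further than this floor because compound 3 sits at a limit of the assay, as compound 1 does: the limit of < 5000 nM in this assay, at which 2 of the 3 values shown sit.

Going by these compounds, how far compound 3 really lies from compound 2 remains open, and so does whether the change carries beyond the usual scatter of repeated measurements. Also open, on these data alone, is what a carboxylic acid or a morpholine ring would give on the same chain carbon in place of pyrazin-2-yl, and whether either would yield a real number in this assay rather than another limit.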